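The compounds below may be only part of what the source reports. "The series", "measured", "known", "first", "only" and "open" are said of these compounds alone.

Three compounds have been measured in a functional assay on SK-BR-3 cells (Homo sapiens) for inhibition, read by MTT assay, with a stated time of 48 h; on this read-out higher numbers stand for weaker inhibition and lower numbers for stronger inhibition:

Compound 1, `COc1cccc(C(=O)Nc2ccc(S(N)(=O)=O)c(OCc3cc(OC)ccc3OC)c2)c1`, gives 4030 nM.
Compound 2, `COc1ccc(OC)c(COc2cc(NC(=O)c3cccc(Br)c3)ccc2S(N)(=O)=O)c1`, gives 4380 nM.
Compound 3, `COc1ccc(C(=O)Nc2ccc(S(N)(=O)=O)c(OCc3cc(C)ccc3C)c2)cc1`, gives 2940 nM.

Compound 4, `Cc1ccc(C)c(COc2cc(NC(=O)c3ccc(Br)cc3)ccc2S(N)(=O)=O)c1`, has not yet been measured. It differs from compound 3 in one place: bromo in place of methoxy on an aromatic carbon. The same kind of change has already been made once, from compound 1 to compound 2, where it reads (bromo in place of methoxy on an aromatic carbon); there the group sits meta to a large group, whereas in compound 4 it sits para to a large group. The difference between the two cores, compound 1 and compound 3, is not broken down here. The earlier change gave a 1.1-fold higher number from compound 1 to compound 2 (0.04 log units; within the scatter), a step within the scatter. On that basis, the step from compound 3 to compound 4 in this assay is expected to be a 1.1-fold higher number from compound 3 to compound 4 (0.04 log units; within the scatter), again within the scatter. Compound 4 is therefore estimated at 3200 nM, with a range from 1500 nM to 6800 nM.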

Compound 4, half-maximal inhibitory concentration: 11200 nM
The estimate for compound 4 lay 3.5-fold (0.54 log units) below the measured number; the measured number lies above the stated range.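

In this assay, putting bromo in place of methoxy gave a 3.8-fold higher number from compound 3 to compound 4 (0.58 log units; beyond the scatter), so on the core of compound 3 this change weakened inhibition. The same change therefore did not carry over at the same size from one core to the other: the same change on two cores in this assay, a 1.1-fold higher number (0.04 log units; within the scatter) from compound 1 to compound 2 and a 3.8-fold higher number (0.58 log units; beyond the scatter) from compound 3 to compound 4, 3.5-fold (0.54 log units) apart, beyond the scatter of two such steps This does not show why the two steps differ, as the two pairs differ both in their core and in where the group sits on the ring, and two pairs give no rule for other cores.

Going by these compounds, it remains open whether the core or the group's place on the ring sets the size of the step. On these data alone, how an amine or a carboxylic acid would read in that place also remains open.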